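Swapping the morpholine ring for thiomorpholine in a thiosemicarbazone

The compounds below may be only part of what the source reports. "The series", "measured", "known", "first", "only" and "open" are said of these compounds alone.

Measured so far:
compound 1 `N/C(=N\NC(=S)N1CCOCC1)c1ccccn1`: 82.8%
compound 2 `Cc1ccnc(/C(N)=N/NC(=S)N2CCOCC2)c1`: 45.2%
compound 3 `N/C(=N\NC(=S)N1CCCC1)c1ccc(F)cn1`: 81.2%

Of the compounds shown here, three share a thiosemicarbazone core and have been tested in a functional assay on HeLa cells (Homo sapiens) for cytotoxicity, read by MTT assay, with a stated time of 72 h, tested at 30 uM; on this read-out higher numbers stand for more inhibition of growth at the one concentration tested and lower numbers for less inhibition of growth. Compound 1 `N/C(=N\NC(=S)N1CCOCC1)c1ccccn1` gives 82.8% and sits highest of the three, though compound 3 `N/C(=N\NC(=S)N1CCCC1)c1ccc(F)cn1` with 81.2% lies within the scatter of it, so no order between these two can be claimed. Among the measured compounds shown here, compound 2 `Cc1ccnc(/C(N)=N/NC(=S)N2CCOCC2)c1` gives 45.2%; the step of a number 37.6 percentage points lower from compound 1 to compound 2 (beyond the scatter) is the only single-place change measured and is large.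

Compound 4 `N/C(=N\NC(=S)N1CCSCC1)c1ccccn1` has not yet been measured. It differs from compound 1 in one place: thiomorpholin-4-yl in place of morpholin-4-yl on a thiocarbonyl carbon. For the measured compounds named here, none of the measured steps bears on this change, since the one measured step concerns a methyl on the aromatic ring, and compound 3 differs from compound 1 in two places at once. The change in compound 4 keeps the ring size, the count of hetero atoms and the acceptor count, so no step beyond the scatter is expected in this assay, in either direction. For compound 4 the expected value is 78%, with a range of 60% to 92%, which is an estimated step of a number 4.8 percentage points lower from compound 1 to compound 4 (within the scatter).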

Compound 4, percent growth inhibition at one concentration: 80.6%
Compound 4: the middle estimate sits 2.6 percentage points below what was measured, within the range that was stated.
By their numbers in this assay, from the lowest: compound 2; then compounds 4, 3 and 1 (each within the scatter of the next).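

In this assay, placing thiomorpholin-4-yl instead of morpholin-4-yl on the thiocarbonyl carbon gives a number 2.2 percentage points lower from compound 1 to compound 4 (within the scatter), so exchanging the oxygen of this ring for sulfur produces no readable change in growth inhibition. Among the compounds shown here, this is the first single-place change measured at this position, whereas the only earlier one, a number 37.6 percentage points lower from compound 1 to compound 2 (beyond the scatter), was a methyl in place of hydrogen on an aromatic carbon, so a large step at that site now stands alongside a step within the scatter at the thiocarbonyl carbon. No supporting data are available to explain why these two rings read alike.

Going by these compounds, both rings compared here are six-membered with two hetero atoms, so it remains open whether this position would tolerate a group of a different kind, such as piperazin-1-yl with a second ring nitrogen or an open-chain dimethylamino group. On these data alone, it is also open whether compound 4 and compound 1 would still match at other concentrations, since a single concentration cannot show how their full dose responses compare.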